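The source may report more compounds than this note shows. Statements on the series, on what has been measured and on what is new or still open speak of the compounds shown alone.

Compounds measured so far:
Compound 1 `COc1ccccc1C[C@H]1COC(=O)[C@@H]1Cc1ccc(Cl)c(Cl)c1`: 14000 nM
Compound 2 `O=C1OC[C@H](Cc2cccc(F)c2)[C@H]1Cc1ccc(Cl)c(Cl)c1`: 14000 nM

In a functional assay on HL-60 cells (Homo sapiens) for cytotoxicity, read by WST assay, with a stated time of 48 h (a higher number here means that more compound is needed for the effect, a lower number that less compound is needed), compound 2 gives 14000 nM, level with compound 1 at the digits reported. Compound 3 `CCc1ccc(C[C@H]2COC(=O)[C@@H]2Cc2ccc(Cl)c(Cl)c2)cc1` has not yet been measured. It carries 4-ethylphenyl in place of 3-fluorophenyl on a saturated chain carbon bound to a saturated ring carbon. For the measured compounds named here, only one measured step bears on this place, no change at the digits printed from compound 1 to compound 2 (within the scatter), and it lies within the scatter. On that evidence, no step beyond the scatter is expected in this assay, and the expected step is no change at the digits printed from compound 2 to compound 3 (within the scatter). Compound 3 is estimated at 14000 nM, with an expected range from 5000 nM to 35000 nM.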

Compound 3, half-maximal effective concentration: 16000 nM
For compound 3 the middle estimate is 1.1-fold (0.06 log units) below the measured one; low and high end bracket the measured number.
By their numbers in this assay, from the lowest: compounds 1, 2 and 3 (each within the scatter of the next).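

In this assay, 4-ethylphenyl joins 2-methoxyphenyl and 3-fluorophenyl on a saturated chain carbon bound to a saturated ring carbon, and neither new step separates the compounds: a 1.1-fold higher number from compound 2 to compound 3 (0.06 log units; within the scatter), and a 1.1-fold higher number from compound 1 to compound 3 (0.06 log units; within the scatter). Across these three substituted phenyl groups, this place therefore shows no measurable response. No measurement offered here explains this.

On these data alone, what remains open is whether a group of another kind at this place, such as an amine or a carboxylic acid, would move the number beyond the scatter.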